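A few compounds are considered here, and "the series" means these few. Any claim that something is new, unique, unknown or untested is made for them only; others in the source may bear on it.

Compound 1 `O=C1NC(=O)/C(=C/C2=Cc3ccccc3OC2)S1`, compound 2 `O=C1NC(=S)S/C1=C\C1=Cc2ccccc2OC1` and compound 3 `O=C1NC(=O)/C(=C/C2=Cc3cc(Br)ccc3OC2)S1` were tested in a functional assay on MOLT-4 cells (Homo sapiens) for antiproliferative activity, read by MTT assay, with a stated time of 72 h; a lower number here means a stronger inhibitor, a higher number a weaker inhibitor. In this assay compound 1 gives 101000 nM, compound 2 gives 52000 nM and compound 3 gives 54700 nM. Compound 3 differs from compound 1 in one place (bromo in place of hydrogen on an aromatic carbon), and this step a 1.8-fold lower number from compound 1 to compound 3 (0.27 log units; within the scatter). The difference between the cores of compound 1 and compound 2 is not broken down here. Compound 4 `O=C1NC(=S)S/C1=C\C1=Cc2cc(Br)ccc2OC1` has not yet been measured; it differs from compound 2 in one place (bromo in place of hydrogen on an aromatic carbon), the same change in the same place as between compound 1 and compound 3. Since that earlier step stayed within the scatter, compound 4 is expected to sit close to compound 2, with a step of about a 1.5-fold lower number from compound 2 to compound 4 (0.17 log units; within the scatter). Compound 4 is therefore estimated at 35000 nM, between 15000 nM and 80000 nM.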

Compound 4, half-maximal inhibitory concentration: 38200 nM
Estimate against measurement, compound 4: 1.1-fold (0.04 log units) below; measured number inside the range.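

In this assay, bromo in place of hydrogen on an aromatic carbon gives a 1.4-fold lower number from compound 2 to compound 4 (0.13 log units; within the scatter), a step too small to count as a real change on its own. Set beside the same change on the other core, the two steps agree: the same change on two cores in this assay, a 1.8-fold lower number (0.27 log units; within the scatter) from compound 1 to compound 3 and a 1.4-fold lower number (0.13 log units; within the scatter) from compound 2 to compound 4, 1.4-fold (0.13 log units) apart, within the scatter of two such steps. This shows that the change behaves alike on these two cores as far as this assay can tell, but it does not show that bromo truly alters activity on either core, and two cores are too few for a general rule.

The compounds shown leave open whether a different group at this place, such as an amine, a carboxylic acid or a longer chain, would shift the number beyond the scatter. They also leave open what bromo would do elsewhere on the aromatic ring.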